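Removing the nitro group from a urea in a cell growth test

The source may hold more compounds than are shown below. What is called first, only, known or untested is meant among the compounds shown, and "the series" means these compounds.

Measured so far:
Compound 1, `COc1ccc(-c2[nH]c3cc(OC)cc(OC)c3c(=O)c2I)cc1`: 49400 nM
Compound 2, `COC(=O)c1cc(=O)c2cc(NC(=O)Nc3ccc(C(F)(F)F)cc3[N+](=O)[O-])ccc2[nH]1`: > 25900 nM

Both compounds were tested in a functional assay on KOPN-8 cells (Homo sapiens) for antiproliferative activity, with a stated time of 72 h; a lower number here means that less compound is needed, a higher number that more compound is needed for the effect. Compound 1 gives a number, but it is a high one. For compound 2 the read-out is not a number but a limit of the assay, > 25900 nM. Compound 2 therefore stands at the limit of > 25900 nM in this assay, at which 1 of the 2 values shown sits, so its own potency is only bounded, not placed.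

The step from compound 2 leads to compound 3, `COC(=O)c1cc(=O)c2cc(NC(=O)Nc3ccc(C(F)(F)F)cc3)ccc2[nH]1`. The change is hydrogen in place of nitro on an aromatic carbon, the carbon sitting ortho to a large group and meta to a trifluoromethyl group. Among the compounds with values here, no step between two measured compounds shows what such a change does here. The account expects the step to be small, if any, and not clearly beyond the scatter in this assay, with the expected step being a step that the limit leaves unreadable from compound 2 to compound 3. Compound 3 is expected to give 30000 nM, between 8000 nM and 100000 nM.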

Compound 3, half-maximal effective concentration: > 6350 nM
Compound 3 was reported as a limit (the forecaster's own chance of this, stated with the estimate: 55%); the middle value is on the limit's open side.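

Compound 2 and compound 3 are both reported only as limits in this assay, so the step between them, hydrogen in place of nitro, cannot be read. The compounds shown leave open where either compound's potency lies and whether this change alters it.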